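A few compounds are considered here, and "the series" means these few. Any claim that something is new, unique, unknown or untested is made for them only; others in the source may bear on it.

Working notes on the series built on the shared core: compound 1 `O=c1cc(I)n([C@@H]2O[C@H](CO)[C@@H](O)[C@H]2O)c(=O)[nH]1`, compound 2 `[N-]=[N+]=Nc1cc(=O)[nH]c(=O)n1[C@@H]1O[C@H](CO)[C@@H](O)[C@H]1O` and compound 3 `Nc1cc(=O)[nH]c(=O)n1[C@@H]1O[C@H](CO)[C@@H](O)[C@H]1O` have been measured, and compound 4 `COC(=O)c1cc(=O)[nH]c(=O)n1[C@@H]1O[C@H](CO)[C@@H](O)[C@H]1O` has not. Within the data shown here, in a functional assay on SKW3 cells (Homo sapiens) for antiproliferative activity, read by WST assay, with a stated time of 3 days (on this read-out lower numbers stand for stronger inhibition and higher numbers for weaker inhibition), compound 1 gives 18900 nM, the only true number in the set. In this assay compound 2 gives > 50000 nM, which is a limit of the assay and not a number. Compound 3 gives > 50000 nM in this assay, again a limit. Compound 2 thus sits at the limit of > 50000 nM in this assay, at which 2 of the 3 values shown sit, so its standing relative to compound 3 cannot be read, while the steps of an at least 2.6-fold higher number from compound 1 to compound 2 (0.42 log units; beyond the scatter) and an at least 2.6-fold higher number from compound 1 to compound 3 (0.42 log units; beyond the scatter) both run beyond the scatter, and the step that the two limits leave unreadable from compound 2 to compound 3 stays unreadable.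

The change to compound 4 is methoxycarbonyl in place of azido on an aromatic carbon. Among the measured compounds shown here, no measured step covers this change itself; what the data show is that both departures from iodo on this carbon have pushed the value to the limit. Compound 4 is therefore expected to sit near that limit as well, with an estimate of 50000 nM and a range of 15000 nM to 200000 nM. The expected step is a number no higher from compound 2 to compound 4 (the limit leaves the size open), nothing readable beyond the scatter.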

Compound 4, half-maximal inhibitory concentration: > 50000 nM
Compound 4 ended at the assay's limit; the forecaster's own chance of this, stated with the estimate: 70%; the middle value lies on the limit itself.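

Methoxycarbonyl on this carbon next to the ring nitrogen brings no nitrogen, unlike azido and amino, yet in this assay replacing iodo gives an at least 2.6-fold higher number from compound 1 to compound 4 (0.42 log units; beyond the scatter). Among the groups shown, the loss at this position is therefore not confined to nitrogen-bearing replacements, and iodo remains the only group with a true number. The steps among compound 2, compound 3 and compound 4 cannot be read, and the set now gathers at a single limit: the limit of > 50000 nM in this assay, at which 3 of the 4 values shown sit.

On these data alone, how far compound 2, compound 3 and compound 4 lie beyond that limit stays open, so no order among azido, amino and methoxycarbonyl can be given. Also open, as far as these compounds go, is whether bromo, chloro or a carboxylic acid on this carbon would give a true number.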